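Notes on an amine-nitrogen substitution step

The compounds below may be only part of what the source reports. "The series", "measured", "known", "first", "only" and "open" are said of these compounds alone.

Measured so far, in a functional assay on U2OS cells (Homo sapiens) for antiproliferative activity, read by MTT assay, with a stated time of 72 h; on this read-out higher numbers stand for weaker inhibition and lower numbers for stronger inhibition:
compound 1 `NC1=C(C(=O)c2ccccc2)C(c2ccc(Br)cc2)N(CCCn2ccnc2)C1=O` gives 149000 nM;
compound 2 `O=C(C1=C(Nc2ccc(F)cc2)C(=O)N(CCCn2ccnc2)C1c1ccc(Br)cc1)c1ccccc1` gives 30000 nM.

Within the data shown here, compound 1 stands as the higher of the two numbers, the only neighbour being compound 2, reached by a 5.0-fold lower number from compound 1 to compound 2 (0.70 log units; beyond the scatter). Among the measured compounds shown here, that single step, 4-fluorophenyl in place of hydrogen on an amine nitrogen, is the only measured change in the set, and it runs to a lower number beyond the scatter.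

Compound 3 `O=C(C1=C(Nc2ccccc2Br)C(=O)N(CCCn2ccnc2)C1c1ccc(Br)cc1)c1ccccc1` differs from compound 1 as follows: 2-bromophenyl in place of hydrogen on an amine nitrogen. For the measured compounds named here, it is the same kind of change as in the one measured step, a phenyl ring carrying one halogen entering at the amine nitrogen, so the step of a 5.0-fold lower number from compound 1 to compound 2 (0.70 log units; beyond the scatter) is the one comparison that bears on it. On that basis a lower number is expected for compound 3, estimated as a 4.3-fold lower number from compound 1 to compound 3 (0.63 log units; beyond the scatter). Going by the values given here, compound 3 is therefore expected at 35000 nM, with a range of 10000 nM to 120000 nM, the width reflecting that only one analogous step exists.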

Compound 3, half-maximal inhibitory concentration: 16900 nM
For compound 3 the middle estimate is 2.1-fold (0.32 log units) above the measured one; the measured number falls inside the stated range.
By their numbers in this assay, from the lowest: compounds 3 and 2 (each within the scatter of the next); then compound 1.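

In this assay, a second halogen-bearing phenyl group on the amine nitrogen also lowers the number, an 8.8-fold lower number from compound 1 to compound 3 (0.95 log units; beyond the scatter), so the drop at this position is not confined to 4-fluorophenyl. Replacing 4-fluorophenyl with 2-bromophenyl gives a 1.8-fold lower number from compound 2 to compound 3 (0.25 log units; within the scatter), which leaves the two substituted compounds unordered at this position. No available evidence bears on what lies behind these steps.

The compounds shown leave open how an unsubstituted phenyl, a benzyl or a methyl group on the same nitrogen would compare, and so whether the halogen or the ring itself goes with the lower numbers. Going by these compounds, because 4-fluorophenyl and 2-bromophenyl differ in both the halogen and its place on the ring, the effect of each of these changes alone also remains open.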